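A few compounds are considered here, and "the series" means these few. Any claim that something is new, unique, unknown or untested is made for them only; others in the source may bear on it.

Measured so far:
compound 1 `CCOCCOc1cccc2ccc(N)nc12`; compound 2 `CCC(C)COc1cccc2ccc(N)nc12`; compound 3 `CC(C)=CCOc1cccc2ccc(N)nc12`.

In an assay on cells with melanin-concentrating hormone receptor 1 (Homo sapiens) as the target, read by radioligand binding (on this read-out higher numbers stand for weaker inhibition and lower numbers for stronger inhibition), compound 1 gives > 2000 nM, a limit of the assay. Compound 2 gives 36 nM. Compound 3 gives > 2000 nM, which is a limit as well. So compound 3 sits at the limit of > 2000 nM in this assay, at which 2 of the 3 values shown sit; the only read number is that of compound 2, reached as an at least 55-fold lower number from compound 1 to compound 2 (1.74 log units; beyond the scatter) and lost again as an at least 55-fold higher number from compound 2 to compound 3 (1.74 log units; beyond the scatter), while a step that the two limits leave unreadable from compound 1 to compound 3.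

Compound 4 `COCCOCCOc1cccc2ccc(N)nc12` carries (2-methoxyethoxy)methyl in place of 2-methylprop-1-en-1-yl on a saturated chain carbon bound to an oxygen on an aromatic ring. For the measured compounds named here, the chain entering resembles the ethoxymethyl of compound 1 more than the sec-butyl of compound 2, and both compound 1 and compound 3 end at the limit, so no step readable beyond the scatter is expected in this assay; compound 4 is expected near 4000 nM (range 1500 nM to 15000 nM), meaning an estimated step that the limit leaves unreadable from compound 3 to compound 4.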

Compound 4, half-maximal inhibitory concentration: > 2000 nM
Compound 4: only a limit was reported; the forecaster's own chance of this, stated with the estimate: 80%; the middle value does not contradict the limit.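

Adding a second ether oxygen to the chain of compound 1 does not bring back a read number in this assay, and compound 4 ends at a limit of the assay: the limit of > 2000 nM in this assay, at which 3 of the 4 values shown sit.
For the compounds shown here, the sec-butyl chain of compound 2 remains the only one with a read number, with an at least 55-fold higher number from compound 2 to compound 4 (1.74 log units; beyond the scatter). Going by these compounds, the steps among the three limits cannot be read, so the ranking of compound 1, compound 3 and compound 4 stays unknown.

On these data alone, whether a straight butyl chain or a cyclopentyl group on this carbon would also give a read number remains open. The compounds shown also leave open whether the branching of sec-butyl matters.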